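Swapping a sulfonyl for a difluoroacetyl on the side chain

This account rests on a few compounds, and the source may have more. Where it says the series, first, only, none or still open, it means among the compounds named here.

Three measured compounds share one core and differ only in the group on a saturated chain carbon bound to a saturated ring carbon. Compound 1 `O=C1O[C@@H](CN2CCCCC2)CN1c1ccc(-n2cc(-c3ccccn3)cn2)c(F)c1` carries piperidin-1-yl there. In an ADME assay on L02 cells (Homo sapiens) for cytotoxicity, read by MTT assay, with a stated time of 48 h (a higher number here means a weaker inhibitor, a lower number a stronger inhibitor), compound 1 gives > 400 ug/mL, which is a limit of the assay rather than a number. Compound 2 `O=C1CSC(=O)N1C[C@H]1CN(c2ccc(-n3cc(-c4ccccn4)cn3)c(F)c2)C(=O)O1` carries 2,4-dioxo-1,3-thiazolidin-3-yl instead. In this assay compound 2 gives > 400 ug/mL, again a limit. Compound 3 `CS(=O)(=O)NC[C@H]1CN(c2ccc(-n3cc(-c4ccccn4)cn3)c(F)c2)C(=O)O1` carries methanesulfonamido. In this assay compound 3 gives > 400 ug/mL, also a limit. Compound 3 thus stands where every other value stands: the limit of > 400 ug/mL in this assay, at which 3 of the 3 values shown sit. The steps a step that the two limits leave unreadable from compound 1 to compound 2, a step that the two limits leave unreadable from compound 1 to compound 3 and a step that the two limits leave unreadable from compound 2 to compound 3 all have no readable size. Compound 4 `O=C(NC[C@H]1CN(c2ccc(-n3cc(-c4ccccn4)cn3)c(F)c2)C(=O)O1)C(F)F` differs from compound 3 in one place: (difluoromethyl)carbonyl in place of methylsulfonyl on an amine nitrogen. Among the compounds with values here, with no measured step offering a readable size, the expected step is a step that the limit leaves unreadable from compound 3 to compound 4, no change beyond the scatter. Compound 4 is expected at 450 ug/mL, within 200 ug/mL to 1000 ug/mL, most likely reported again only as a limit.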

Compound 4, half-maximal inhibitory concentration: > 400 ug/mL
Compound 4 was reported as a limit (the forecaster's own chance of this, stated with the estimate: 80%); the middle value lies beyond the limit too.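

In this assay compound 4 gives > 400 ug/mL, again a limit. The steps from compound 4 to compound 1, compound 2 and compound 3 cannot be read, and all four compounds stand at one place: the limit of > 400 ug/mL in this assay, at which 4 of the 4 values shown sit.

Whether these side-chain groups differ at all in their effect on the cells stays open, with no compound shown giving a number rather than a limit.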